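Hydroxy to methoxy on a shared core

The source may hold more compounds than are shown below. What is called first, only, known or untested is meant among the compounds shown, and "the series" means these compounds.

- compound 1 `CONC(=S)N/N=C1\C(=O)N(CN(C)C)c2ccc(F)cc21`: 560000 nM
- compound 2 `CCN(CC)CN1C(=O)/C(=N\NC(=S)NOC)c2cc(C)ccc21`: 573000 nM
- compound 3 `CCN(CC)CN1C(=O)/C(=N\NC(=S)NO)c2cc(F)ccc21`: 521000 nM

These three compounds were tested in an ADME assay on MT4 cells (Homo sapiens) for cytotoxicity, read by spectrophotometry, with a stated time of 5 days; on this read-out lower numbers stand for higher toxicity in this test and higher numbers for lower toxicity in this test. Compound 3 gives 521000 nM, which lies within the usual scatter of the other two values, so the measurements cannot tell the three compounds apart. Compound 4 `CCN(CC)CN1C(=O)/C(=N\NC(=S)NOC)c2cc(F)ccc21` differs from compound 3 in one place: methyl in place of hydrogen on an oxygen. In words, this is methyl in place of hydrogen on an oxygen, turning hydroxy to methoxy. Among the measured compounds shown here, no measured pair differs by this change alone, so there is no direct precedent for its size. Still, compound 1 carries the methoxy group and gives 560000 nM. Compound 2 carries it too and gives 573000 nM. Neither value stands apart from that of compound 3, so no step beyond the scatter is expected in this assay. The estimated change is a 1.1-fold higher number from compound 3 to compound 4 (0.02 log units; within the scatter). For compound 4 the estimated value is 550000 nM, with an expected range from 350000 nM to 850000 nM.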

Compound 4, half-maximal cytotoxic concentration: 490000 nM
The estimate for compound 4 lay 1.1-fold (0.05 log units) above the measured number; measured number inside the range.
By their numbers in this assay, from the lowest: compounds 4, 3, 1 and 2 (each within the scatter of the next).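

In this assay, the change from hydroxy to methoxy can now be read directly, and on this oxygen it gives (a 1.1-fold lower number from compound 3 to compound 4 (0.03 log units; within the scatter)), so the methyl group leaves no measurable mark on the read-out. Compound 4 also links the other two methoxy compounds to this series: fluoro in place of methyl on an aromatic carbon gives (a 1.2-fold lower number from compound 2 to compound 4 (0.07 log units; within the scatter)), and diethylamino in place of dimethylamino on a saturated chain carbon gives (a 1.1-fold lower number from compound 1 to compound 4 (0.06 log units; within the scatter)). No measurement shown here offers an explanation for how closely these numbers agree. As far as these compounds go, whether a longer chain such as propyl, or a bulkier benzyl group, on this same oxygen would shift the number remains open. So does the effect of an amine or a carboxylic acid in that place.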